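The source may hold more compounds than are shown below. What is called first, only, known or untested is meant among the compounds shown, and "the series" means these compounds.

Measured compounds:
Compound 1, `COC(=O)c1ccc(-c2cnc(C(O)CCc3ccc(-c4ccccc4)cc3)o2)nc1`: in an assay for inhibition of Fatty-acid amide hydrolase 1 (Rattus norvegicus) (on this read-out lower numbers stand for stronger inhibition and higher numbers for weaker inhibition), compound 1 gives 1100 nM.
Compound 2, `CN(C)C(=O)c1cnc(C(=O)CCc2ccc(Oc3ccccc3)cc2)o1`: in this assay compound 2 gives 5.4 nM.

Compound 2 stands lowest of the two numbers; its nearest neighbour, compound 1, sits far higher, well beyond the scatter. Going by the values given here, the two differ in several places at once, so no single step can be drawn between them.

Compound 3, `CN(C)C(=O)c1cnc(C(=O)CCc2ccc(-c3ccccc3)cc2)o1`, has not yet been measured. It differs from compound 2 in one place: phenyl in place of phenoxy on an aromatic carbon. Among the compounds with values here, no measured pair shows this exact exchange, so its size cannot be read from the data; the expectation is a step of modest size, likely a slight rise, and possibly none beyond the scatter. The step expected from that reading is a 1.9-fold higher number from compound 2 to compound 3 (0.27 log units; within the scatter). In this assay compound 3 is estimated to give 10 nM, within a range from 3 nM to 40 nM.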

Compound 3, inhibition constant: 3 nM
Estimate against measurement, compound 3: 3.3-fold (0.52 log units) above; low and high end bracket the measured number.
By their numbers in this assay, from the lowest: compounds 3 and 2 (each within the scatter of the next); then compound 1.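

In this assay, phenyl in place of phenoxy on an aromatic carbon, para to a large group, gives a 1.8-fold lower number from compound 2 to compound 3 (0.26 log units; within the scatter). Going by these compounds alone, this is the first single exchange that can be read, and it shows that the number stays within the scatter when this substituent loses its oxygen, along with the one hydrogen-bond acceptor counted for phenoxy. Nothing at hand bears on why the two groups read alike.

As far as these compounds go, whether this position would accept a benzyl group, a cyclohexyl ring or a carboxylic acid in the same way remains open. Steps to compound 1 cannot be read, since it differs from compound 2 and compound 3 in several places, so the separate contributions of its hydroxyl group and its methyl ester remain open too.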